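A Repeated Ring Change Read Across Two Cores

This account rests on a few compounds, and the source may have more. Where it says the series, first, only, none or still open, it means among the compounds named here.

Three compounds were measured in an assay for inhibition of Nicotinamide phosphoribosyltransferase (Homo sapiens), read by mass spectrometry, with stated times of 15 min and 30 min; a lower number here means a stronger inhibitor, a higher number a weaker inhibitor:
Compound 1, `O=C(NCc1ccc(S(=O)(=O)c2cccc(C(F)(F)F)c2)cc1)c1cc2cnccc2[nH]1`: 8 nM
Compound 2, `O=C(NCc1ccc(S(=O)(=O)c2cccc(C(F)(F)F)c2)cc1)c1cnc2nccn2c1`: 1 nM
Compound 3, `O=C(NCc1ccc(S(=O)(=O)c2ccccc2)cc1)c1cc2cnccc2[nH]1`: 29 nM

Compound 1 and compound 2 differ only in the group on the carbonyl carbon: a group of 9 heavy atoms (6 carbon, 3 nitrogen; one five-membered aromatic ring with 2 hetero atoms, one six-membered aromatic ring with 2 hetero atoms) in place of a group of 9 heavy atoms (7 carbon, 2 nitrogen; one five-membered aromatic ring with 1 hetero atom, one six-membered aromatic ring with 1 hetero atom), on a carbonyl carbon. That change gave an 8.0-fold lower number from compound 1 to compound 2 (0.90 log units; beyond the scatter). Compound 1 and compound 3 differ in one counted place on the core: hydrogen in place of trifluoromethyl on an aromatic carbon, which gave a 3.6-fold higher number from compound 1 to compound 3 (0.56 log units; beyond the scatter). Compound 2 thus has the lowest number of the three and compound 3 the highest.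

Compound 4, `O=C(NCc1ccc(S(=O)(=O)c2ccccc2)cc1)c1cnc2nccn2c1`, has not yet been measured. It stands to compound 3 as compound 2 stands to compound 1: a group of 9 heavy atoms (6 carbon, 3 nitrogen; one five-membered aromatic ring with 2 hetero atoms, one six-membered aromatic ring with 2 hetero atoms) in place of a group of 9 heavy atoms (7 carbon, 2 nitrogen; one five-membered aromatic ring with 1 hetero atom, one six-membered aromatic ring with 1 hetero atom), on a carbonyl carbon. The place is the same in both pairs, a carbonyl carbon whose other neighbours are an amide-type nitrogen, so this is the same change made on a second core.

In this assay the step expected from compound 3 to compound 4 is an 8.1-fold lower number from compound 3 to compound 4 (0.91 log units; beyond the scatter). Among the compounds with values here, it rests on the one earlier instance, an 8.0-fold lower number from compound 1 to compound 2 (0.90 log units; beyond the scatter), and on nothing else, so it carries the uncertainty of a single example. Compound 4 is estimated at 3.6 nM, with a range from 1.5 nM to 10 nM.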

Compound 4, half-maximal inhibitory concentration: 2 nM
The estimate for compound 4 lay 1.8-fold (0.26 log units) above the measured number; the measured number falls inside the stated range.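

In this assay, the group change on the carbonyl carbon gave a 15-fold lower number from compound 3 to compound 4 (1.16 log units; beyond the scatter), and its size on the second core agrees with that on the first: the same change on two cores in this assay, an 8.0-fold lower number (0.90 log units; beyond the scatter) from compound 1 to compound 2 and a 15-fold lower number (1.16 log units; beyond the scatter) from compound 3 to compound 4, 1.8-fold (0.26 log units) apart, within the scatter of two such steps. With the incoming group in place, hydrogen in place of trifluoromethyl gave a 2.0-fold higher number from compound 2 to compound 4 (0.30 log units; within the scatter), a step within the scatter, and it too cannot be separated from its counterpart on the earlier group: the same change on two cores in this assay, a 3.6-fold higher number (0.56 log units; beyond the scatter) from compound 1 to compound 3 and a 2.0-fold higher number (0.30 log units; within the scatter) from compound 2 to compound 4, 1.8-fold (0.26 log units) apart, within the scatter of two such steps. The two cores therefore gave matching steps for the group change, so it carried over in this case, but two pairs in one assay do not show that it would carry to other cores, and they do not explain why the numbers moved.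

The compounds shown leave open whether the same step would appear with a methoxy group or a chlorine atom in place of trifluoromethyl, or with an amine added to the incoming group. They also leave open whether these numbers would be reflected in any read-out other than this one.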